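Shortening the Amine Side Chain of Compound 1

The source may hold more compounds than are shown below. What is called first, only, known or untested is meant among the compounds shown, and "the series" means these compounds.

Measured compounds:
compound 1, `CC(C)(O)CNCCCOc1ccc([C@H]2CC[C@]3(CC2)OOC2(O3)C3CC4CC(C3)CC2C4)cc1`: > 100 ug/mL
compound 2, `CC(C)(O)CN1CCC(Oc2ccc([C@H]3CC[C@]4(CC3)OOC3(O4)C4CC5CC(C4)CC3C5)cc2)CC1`: 1.6 ug/mL
compound 3, `c1cc([C@H]2CC[C@]3(CC2)OOC2(O3)C3CC4CC(C3)CC2C4)ccc1OCC1CCNCC1`: 12.5 ug/mL

Three compounds share one core and differ only in the amine-bearing chain on the aryl oxygen. In a physicochemical assay for solubility, read by nephelometry, measured as kinetic solubility, with a stated time of 30 min (a lower number here means a less soluble compound, a higher number a more soluble compound), compound 1 reaches > 100 ug/mL, which is a limit of the assay and not a number (the limit of > 100 ug/mL in this assay, at which 1 of the 3 values shown sits). Compound 2 gives 1.6 ug/mL in this assay, and compound 3 gives 12.5 ug/mL. The measured steps are an at least 62-fold lower number from compound 1 to compound 2 (1.79 log units; beyond the scatter), an at least 8.0-fold lower number from compound 1 to compound 3 (0.90 log units; beyond the scatter) and a 7.8-fold higher number from compound 2 to compound 3 (0.89 log units; beyond the scatter).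

Compound 4, `NCCCCOc1ccc([C@H]2CC[C@]3(CC2)OOC2(O3)C3CC4CC(C3)CC2C4)cc1`, has not yet been measured in this assay. It differs from compound 1 in one place: aminomethyl in place of (2-hydroxy-2-methylpropyl)amino on a saturated chain carbon, three bonds along the chain from an oxygen on an aromatic ring. For the measured compounds named here, none of the measured steps makes this exact change. The nearest is the removal of the same (2-hydroxy-2-methylpropyl) group in a 7.8-fold higher number from compound 2 to compound 3 (0.89 log units; beyond the scatter), a modest rise. Compound 1 already sits at the limit of this assay (the limit of > 100 ug/mL in this assay, at which 1 of the 3 values shown sits), so a rise cannot be read and a fall beyond the scatter is not expected. The step expected is a number no higher from compound 1 to compound 4 (the limit leaves the size open). Compound 4 is therefore estimated at 100 ug/mL, within a range from 35 ug/mL to 250 ug/mL, most probably again reported as a limit.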

Compound 4, solubility: 50 ug/mL
Estimate against measurement, compound 4: 2.0-fold (0.30 log units) above, and the stated range covers the measured number.
By their numbers in this assay, from the lowest: compound 2; then compound 3; then compound 4. At a limit, above all of these: compound 1.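

Compound 1 stands at a limit in this assay, and that is not a number: the limit of > 100 ug/mL in this assay, at which 1 of the 4 values shown sits. Against it, aminomethyl in place of (2-hydroxy-2-methylpropyl)amino, on a saturated chain carbon three bonds along the chain from an oxygen on an aromatic ring, gives an at least 2.0-fold lower number from compound 1 to compound 4 (0.30 log units; that floor lies within the scatter), so this change at this position has no firm fall behind it, and the open chain without the (2-hydroxy-2-methylpropyl) group still gives a number at the top of the measured values. The earlier compounds shown here carried no such unsubstituted open chain, and the 4-aminobutyl group of compound 4 now stands clear of both piperidine-bearing compounds, with a 4.0-fold higher number from compound 3 to compound 4 (0.60 log units; beyond the scatter) and a 31-fold higher number from compound 2 to compound 4 (1.49 log units; beyond the scatter).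

The compounds shown leave open how far the true value of compound 1 lies past its limit, and so the real size of the step to compound 4 stays unfixed. They also leave open whether a shorter or a longer chain ending in the same amine, or a dimethylamino group or a carboxylic acid at the chain end, would hold this number.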